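A side-group swap: compound 2 to compound 4

This account rests on a few compounds, and the source may have more. Where it says the series, first, only, none or still open, it means among the compounds named here.

Of the compounds shown here, three sharing one core have been read in an ADME assay on L02 cells (Homo sapiens) for cytotoxicity, read by MTT assay; on this read-out lower numbers stand for stronger inhibition and higher numbers for weaker inhibition. Compound 1 `C=CCOc1cc(/C=C/C(=O)c2ccc(OC)c3c2OC(C)(C)C=C3)ccc1OC` gives > 20000 nM, which is a limit of the assay and not a number. Compound 2 `CCCCC(=O)Oc1cc(/C=C/C(=O)c2ccc(OC)c3c2OC(C)(C)C=C3)ccc1OC` gives > 10000 nM, and this too is only a limit. Among the measured compounds shown here, compound 3 `COc1ccc(/C=C/C(=O)Oc2cc(/C=C/C(=O)c3ccc(OC)c4c3OC(C)(C)C=C4)ccc2OC)cc1` gives 18000 nM, the one true number of the three. Compound 2 therefore has no measured number of its own.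

Compound 4 `COc1ccc(/C=C/C(=O)c2ccc(OC)c3c2OC(C)(C)C=C3)cc1CS(C)(=O)=O` has not yet been measured. Its difference from compound 2 is this: (methylsulfonyl)methyl in place of (butylcarbonyl)oxy on an aromatic carbon. In words, (methylsulfonyl)methyl stands in place of (butylcarbonyl)oxy on an aromatic carbon, ortho to a methoxy group.

For the measured compounds named here, three measured steps bear on this change. There is a step that the two limits leave unreadable from compound 1 to compound 2, there is a step that the limit leaves unreadable from compound 2 to compound 3, and there is an at least 1.1-fold lower number from compound 1 to compound 3 (0.04 log units; that floor lies within the scatter). None of them shows a readable step beyond the scatter, and all of them keep the oxygen that compound 4 gives up, so they guide the expectation only loosely. No large step is expected in this assay, and the expected value stays in the same high range. The estimated step is a step that the limit leaves unreadable from compound 2 to compound 4. A report of only a limit would not be surprising. For compound 4 the estimate is 18000 nM, with an expected range of 8000 nM to 40000 nM.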

Compound 4, half-maximal inhibitory concentration: > 10000 nM
Compound 4 gave a limit, no number (the forecaster's own chance of this, stated with the estimate: 50%); the middle value lies beyond the limit too.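

Among the compounds shown here, compound 4, like compound 1 and compound 2, carries only a limit in this assay and not a number, so no step from either of them to compound 4 can be read. The compounds shown leave open where the value of compound 4 lies, and so what (methylsulfonyl)methyl in place of (butylcarbonyl)oxy or allyloxy does to the read-out.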